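Vinyl in Place of 2-Methylprop-1-en-1-yl on Compound 3

The source may report more compounds than this note shows. Statements on the series, on what has been measured and on what is new or still open speak of the compounds shown alone.

Measured so far:
Compound 1 `CCOc1cc(/C=C2\SC(=O)NC2=O)ccc1OCC1(C)CCc2c(C)c(OCC=C(C)C)c(C)c(C)c2O1`: 84%
Compound 2 `C=CCOc1c(C)c(C)c2c(c1C)CCC(C)(COc1ccc(/C=C3\SC(=O)NC3=O)cc1OCC)O2`: 87%
Compound 3 `CC(C)=CCOc1c(C)c(C)c2c(c1C)CCC(C)(COc1ccc(/C=C3\SC(=O)NC3=O)cc1Br)O2`: 84%

In a functional assay on MCF7 cells (Homo sapiens), tested at 5 uM (on this read-out higher numbers stand for a weaker effect at the one concentration tested and lower numbers for a stronger effect), compound 1 gives 84%, compound 2 gives 87% and compound 3 gives 84%. Compound 3 thus stands level with compound 1 at the digits shown, the bromo-for-ethoxy exchange having produced no change at the digits printed from compound 1 to compound 3 (within the scatter). Compound 2 sits near both of them, the exchange of vinyl for 2-methylprop-1-en-1-yl having produced a number 3 percentage points higher from compound 1 to compound 2 (within the scatter). All three numbers lie within the scatter of one another, so none can be called stronger or weaker than the others.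

Compound 4 `C=CCOc1c(C)c(C)c2c(c1C)CCC(C)(COc1ccc(/C=C3\SC(=O)NC3=O)cc1Br)O2` differs from compound 3 by vinyl in place of 2-methylprop-1-en-1-yl on a saturated chain carbon bound to an oxygen on an aromatic ring. Going by the values given here, the one measured step that bears directly on this change is the same exchange made on the ethoxy analogue, a number 3 percentage points higher from compound 1 to compound 2 (within the scatter), which stayed within the scatter. As the bromo-for-ethoxy exchange no change at the digits printed from compound 1 to compound 3 (within the scatter) also stayed within the scatter, nothing among the three numbers points to a shift beyond the scatter when the same exchange is made on the bromo analogue. The step is therefore expected to be a number 2 percentage points higher from compound 3 to compound 4 (within the scatter) in this assay, no larger than the scatter. Compound 4 is estimated at 86% in this assay, with a range from 77% to 95%.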

Compound 4, a percentage reported as activity, at one concentration (the size of the read-out at that concentration, not a potency): 98%
For compound 4 the middle estimate is 12 percentage points below the measured one, and the stated range ends below it.
By their numbers in this assay, from the lowest: compounds 1, 3 and 2 (each within the scatter of the next); then compound 4.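

In this assay, vinyl in place of 2-methylprop-1-en-1-yl on a saturated chain carbon bound to an oxygen on an aromatic ring now gives a step beyond the scatter, a number 14 percentage points higher from compound 3 to compound 4 (beyond the scatter), yet the two readings of this change do not differ reliably: the same change on two cores in this assay, a number 3 percentage points higher (within the scatter) from compound 1 to compound 2 and a number 14 percentage points higher (beyond the scatter) from compound 3 to compound 4, 11 percentage points apart, within the scatter of two such steps. Bromo in place of ethoxy on an aromatic carbon likewise passes the scatter when vinyl is present, a number 11 percentage points higher from compound 2 to compound 4 (beyond the scatter), and here too the two readings cannot be separated: the same change on two cores in this assay, no change at the digits printed (within the scatter) from compound 1 to compound 3 and a number 11 percentage points higher (beyond the scatter) from compound 2 to compound 4, 11 percentage points apart, within the scatter of two such steps. Compound 4, which carries both the vinyl and the bromo, is thus set apart from compound 2 and compound 3 by steps beyond the scatter, but the four numbers do not establish that either change depends on the core it is made on.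

As far as these compounds go, it remains open whether a saturated propyl chain or a longer chain such as geranyl in place of the allyl of compound 4 would keep the number near that of compound 3 or that of compound 4. Each number also comes from a single concentration, so these steps say nothing about potency.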